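Phenoxy in place of 4-methoxybenzyl on compound 3

This account rests on a few compounds, and the source may have more. Where it says the series, first, only, none or still open, it means among the compounds named here.

Compound 1 `Cc1ccc(CC(C)(Oc2ccc(C(C)C)cc2)C(=O)O)cc1` gives < 1 mg/kg as a limit
Compound 2 `CC(C)c1ccc(OC(C)(Cc2ccc3ccccc3c2)C(=O)O)cc1` gives > 10 mg/kg as a limit
Compound 3 `COc1ccc(Cc2ccc(OC(C)(Cc3ccc(Cl)cc3)C(=O)O)cc2)cc1` gives < 10 mg/kg as a limit

All three results come from a functional assay on the whole organism for inhibition, with Rattus norvegicus as the target (a lower number here means that less compound is needed, a higher number that more compound is needed for the effect), and each of them is a limit, not a number. Compound 3 stands at < 10 mg/kg in this assay and this too is only a limit. As far as these compounds go, its true dose therefore remains open, and the three results give no firm order that includes it.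

Compound 4 `CC(Cc1ccc(Cl)cc1)(Oc1ccc(Oc2ccccc2)cc1)C(=O)O` has phenoxy in place of 4-methoxybenzyl on an aromatic carbon, para to a large group (phenoxy in place of 4-methoxybenzyl on an aromatic carbon) and otherwise matches compound 3. Going by the values given here, no two measured compounds differ in one place, so the size of such a change has not been seen directly. The expectation leans on compound 3 with its limit of < 10 mg/kg as the closest measured structure. The expected step is a step that the limit leaves unreadable from compound 3 to compound 4 and no shift beyond the usual scatter is expected in either direction. For compound 4 the expected dose is 6 mg/kg within an estimated range of 1.5 mg/kg to 25 mg/kg in this assay once it is measured.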

Compound 4, dose for half-maximal effect: < 1 mg/kg
Compound 4: no number, only a limit; the forecaster's own chance of this, stated with the estimate: 55%; at least 6.0-fold (0.77 log units) between middle value and limit.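

Compound 3 and compound 4 are both recorded only as limits in this assay, so the step from compound 3 to compound 4 cannot be read. The compounds shown leave open the true dose of each compound, and with it whether exchanging 4-methoxybenzyl for phenoxy changes the dose needed at all.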